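The compounds below may be only part of what the source reports. "The series", "measured", "known", "first", "only" and "open" are said of these compounds alone.

Among the compounds with values here, compound 3 `CCC(=O)c1ccc2c(c1O)[C@@H]1c3c(ccc4c(=O)c(-c5ccccc5)c(C)oc34)OC[C@@H]1C(C)(C)O2` is the one member of this small set that yields a number in a functional assay on A549 cells (Homo sapiens) for cytotoxicity, read by MTT assay; on this read-out lower numbers stand for stronger inhibition and higher numbers for weaker inhibition: compound 3 gives 19300 nM. Its two companions reach only a limit. Compound 1 `CCC(=O)c1ccc2c(c1O)[C@@H]1c3c(ccc4c(=O)c(C)c(C)oc34)OC[C@@H]1C(C)(C)O2` gives in this assay the limit > 100000 nM. Compound 2 `CC(=O)c1ccc2c(c1O)[C@@H]1c3c(ccc4c(=O)c(C)c(C)oc34)OC[C@@H]1C(C)(C)O2` gives in this assay the limit > 100000 nM. Exchanging methyl for phenyl on an aromatic carbon gives an at least 5.1-fold lower number from compound 1 to compound 3 (0.71 log units; beyond the scatter). The other measured step, a step that the two limits leave unreadable from compound 1 to compound 2, cannot be sized because both of its ends sit at the limit of > 100000 nM in this assay, at which 2 of the 3 values shown sit.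

Compound 4 `CC(=O)c1ccc2c(c1O)[C@@H]1c3c(ccc4c(=O)c(-c5ccccc5)c(C)oc34)OC[C@@H]1C(C)(C)O2` differs from compound 3 by hydrogen in place of methyl on a saturated chain carbon bound to a carbonyl carbon. Within the data shown here, the one measured step of this same kind is a step that the two limits leave unreadable from compound 1 to compound 2, and it says nothing about size because of the limit of > 100000 nM in this assay, at which 2 of the 3 values shown sit. The remaining step, an at least 5.1-fold lower number from compound 1 to compound 3 (0.71 log units; beyond the scatter), concerns a different change and does not bear on this one. With no readable guide, the step is expected to be no change at the digits printed from compound 3 to compound 4 (within the scatter), that is, nothing beyond the scatter. Compound 4 is therefore estimated at 19300 nM, with a range from 7000 nM to 55000 nM.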

Compound 4, half-maximal inhibitory concentration: 2530 nM
The estimate for compound 4 lay 7.6-fold (0.88 log units) above the measured number; the whole stated range lies above it.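

The acetyl and propanoyl pair now gives a readable size for the change at this position in this assay, with a 7.6-fold lower number from compound 3 to compound 4 (0.88 log units; beyond the scatter). So hydrogen in place of methyl on a saturated chain carbon bound to a carbonyl carbon is not silent here, at least where phenyl is present on the shared core. The phenyl change also reads on the acetyl side, with an at least 39-fold lower number from compound 2 to compound 4 (1.59 log units; beyond the scatter), and the two readings of that change cannot be ranked: the same change on two cores in this assay, an at least 5.1-fold lower number (0.71 log units; beyond the scatter) from compound 1 to compound 3 and an at least 39-fold lower number (1.59 log units; beyond the scatter) from compound 2 to compound 4; the limit leaves it open whether they differ.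

Whether ethyl to methyl matters at all on the core of compound 1 stays unreadable, and the other steps that end at a limit cannot be read either: the limit of > 100000 nM in this assay, at which 2 of the 4 values shown sit. Nor do the compounds shown tell how butanoyl, a longer chain, or an amine would read in place of the acetyl of compound 4.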